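Removing the Dimethylamino Group from a Pyrazolone Imine

This account rests on a few compounds, and the source may have more. Where it says the series, first, only, none or still open, it means among the compounds named here.

Of the compounds shown here, three share one core and have been tested in a functional assay on HCT-116 cells (Homo sapiens) for cytotoxicity, read by MTT assay, with a stated time of 72 h; on this read-out lower numbers stand for stronger inhibition and higher numbers for weaker inhibition. Compound 1 `Cc1c(/N=C/c2ccc(N(C)C)cc2)c(=O)n(-c2ccccc2)n1C` gives 832000000 nM and stands second highest of the three numbers. Compound 2 `CCOc1cccc(/C=N/c2c(C)n(C)n(-c3ccccc3)c2=O)c1` gives 933000000 nM, within the scatter of compound 1. Compound 3 `COc1ccccc1/C=N/c1c(C)n(C)n(-c2ccccc2)c1=O` gives 324000000 nM, a lower number beyond the scatter. Compound 4 `Cc1c(/N=C/c2ccccc2)c(=O)n(-c2ccccc2)n1C` is not yet measured; it differs from compound 1 by hydrogen in place of dimethylamino on an aromatic carbon. Among the measured compounds shown here, no measured pair isolates this change, so its size is uncertain. Given the close readings of compounds 1 and 2, the step from compound 1 to compound 4 is expected to be small, a 1.0-fold lower number from compound 1 to compound 4 (0.02 log units; within the scatter), none beyond the scatter in this assay. Compound 4 is therefore estimated at 800000000 nM, ranging from 300000000 nM to 2000000000 nM.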

Compound 4, half-maximal inhibitory concentration: 589000000 nM
Compound 4: the middle estimate sits 1.4-fold (0.13 log units) above what was measured; low and high end bracket the measured number.
By their numbers in this assay, from the lowest: compounds 3, 4, 1 and 2 (each within the scatter of the next, the first and the last beyond it).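

In this assay, among the compounds shown here, compound 4 gives the first reading for this position with no substituent on the ring. Taking away the dimethylamino group gives a 1.4-fold lower number from compound 1 to compound 4 (0.15 log units; within the scatter), so this change does not separate the two compounds. The other two replacements, a 1.8-fold higher number from compound 3 to compound 4 (0.26 log units; within the scatter) for methoxy and a 1.6-fold lower number from compound 2 to compound 4 (0.20 log units; within the scatter) for ethoxy, also stay within the scatter, so hydrogen here reads like each of the three groups it replaces.

From the compounds shown here alone, whether a carboxylic acid, a primary amine or a fluorine atom at this position would give a reading beyond the scatter stays open. Nothing given here explains these readings.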